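The source may hold more compounds than are shown below. What is called first, only, known or untested is meant among the compounds shown, and "the series" means these compounds.

Compound 1 `O=C(CCCCCCc1ccccc1)c1nnc(-c2cccs2)s1`: > 10000 nM.
Compound 2 `COc1coc(C(=O)CCCCCCc2ccccc2)n1`: > 10000 nM.
Compound 3 `CC(=O)c1cnc(C(=O)CCCCCCc2ccccc2)o1`: > 10000 nM.

All three were tested in an assay on HEK-293T cells for inhibition of diacylglycerol lipase-alpha (Homo sapiens), read by colorimetric assay; a higher number here means a weaker inhibitor, a lower number a stronger inhibitor. For compound 1 the value > 10000 nM is a limit of the assay, not a number. Compound 2 likewise gives only the limit > 10000 nM. Compound 3 too stops at > 10000 nM, a limit. Compound 3 therefore stands with the others at the limit of > 10000 nM in this assay, at which 3 of the 3 values shown sit, and no ranking among them is possible.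

Compound 4 `O=C(CCCCCCc1ccccc1)c1ncc(-c2ccccc2F)o1` differs from compound 3 by 2-fluorophenyl in place of acetyl on an aromatic carbon. Among the compounds with values here, no measured pair shows a change of this kind, so the step in this assay is untested; with every value at the limit, it can only go toward stronger inhibition or stay beyond reach. Compound 4 is expected near 3000 nM, within 300 nM to 10000 nM. The expected step of an at least 3.3-fold lower number from compound 3 to compound 4 (0.52 log units; beyond the scatter) is thus toward stronger inhibition, if a number is returned at all.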

Compound 4, half-maximal inhibitory concentration: > 10000 nM
Compound 4: a limit, no number; the forecaster's own chance of this, stated with the estimate: 50%; at least 3.3-fold (0.52 log units) between middle value and limit.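

Within the data shown here, compound 3 and compound 4 both end at a limit, not a number, so no step between them can be read: the limit of > 10000 nM in this assay, at which 4 of the 4 values shown sit. The compounds shown leave open which change to the shared core, if any, would return a measurable value.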